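The compounds below may be only part of what the source reports. "The series", "measured", "known", "first", "only" and "open" are said of these compounds alone.

Measured in an ADME assay on Huh-7 cells (Homo sapiens) for cytotoxicity, with a stated time of 72 h; on this read-out lower numbers stand for higher toxicity in this test and higher numbers for lower toxicity in this test:
- Compound 1 `CC(C)CCn1nc(-c2cccs2)c(O)c(C2=NS(=O)(=O)c3cc(NS(=O)(=O)C4CC4)ccc3N2)c1=O` gives > 1000 nM, which is a limit.
- Compound 2 `CC(C)CCn1nc(-c2cccs2)c(O)c(C2=NS(=O)(=O)c3cc(NS(=O)(=O)C(C)C)ccc3N2)c1=O` gives > 1000 nM, which is a limit.
- Compound 3 `CC(C)CCn1nc(-c2cccs2)c(O)c(C2=NS(=O)(=O)c3cc(N(C)S(C)(=O)=O)ccc3N2)c1=O` gives > 33000 nM, which is a limit.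

Compound 3 has no exact number and stands only at the limit of > 33000 nM in this assay, at which 1 of the 3 values shown sits. Compounds 1 and 2 stand at the limit of > 1000 nM in this assay, at which 2 of the 3 values shown sit. Compound 4 `COCN(c1ccc2c(c1)S(=O)(=O)N=C(c1c(O)c(-c3cccs3)nn(CCC(C)C)c1=O)N2)S(C)(=O)=O` turns methyl into methoxymethyl on the sulfonamide nitrogen of compound 3 (methoxy in place of hydrogen on a saturated chain carbon bound to a sulfonamide nitrogen). The measured steps that bear on this change are a step that the two limits leave unreadable from compound 1 to compound 3 and a step that the two limits leave unreadable from compound 2 to compound 3, and neither has a readable size. The same holds for a step that the two limits leave unreadable from compound 1 to compound 2. No step beyond the usual scatter is therefore expected in this assay, and no direction is favoured. The estimated change is a number no higher from compound 3 to compound 4 (the limit leaves the size open). Compound 4 is expected at 33000 nM. Its estimated range runs from 10000 nM to 100000 nM.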

Compound 4, half-maximal cytotoxic concentration: > 1000 nM
Compound 4: only a limit was reported (the forecaster's own chance of this, stated with the estimate: 80%); the middle value is on the limit's open side.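

Among these compounds, compound 4, like compounds 1, 2 and 3, is reported only as a limit, so no step between any of them can be read. The compounds shown leave open how far each true cytotoxic concentration lies beyond its limit, and whether methoxy in place of hydrogen changes it.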